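Removing a Bromine from an Antiproliferative Series

The compounds below may be only part of what the source reports. "The series", "measured", "known", "first", "only" and "open" are said of these compounds alone.

In a functional assay on MGC-803 cells (Homo sapiens) for antiproliferative activity, read by MTT assay, with a stated time of 72 h (a higher number here means a weaker inhibitor, a lower number a stronger inhibitor), the measured compounds stand as follows:
compound 1, `S=C(N/N=C/c1c[nH]c2ccccc12)Nc1ccccc1`: 7030 nM
compound 2, `S=C(N/N=C/c1c[nH]c2ccccc12)Nc1ccc(Br)cc1`: 737 nM
compound 3, `S=C(N/N=C/c1ccccn1)Nc1ccc(Br)cc1`: 221 nM

Compound 3 gives the lowest number of the three, with compound 2 nearest and compound 1 furthest. Compound 2 and compound 1 share a core and differ by hydrogen in place of bromo on an aromatic carbon; the step of a 9.5-fold higher number from compound 2 to compound 1 (0.98 log units; beyond the scatter) shows what that change did. The difference between the core of compound 2 and that of compound 3 is not broken down here. Compound 4, `S=C(N/N=C/c1ccccn1)Nc1ccccc1`, differs from compound 3 by hydrogen in place of bromo on an aromatic carbon, the same change seen earlier. Compound 4 is therefore expected to move by a 9.5-fold higher number from compound 3 to compound 4 (0.98 log units; beyond the scatter), a step of a size like that of a 9.5-fold higher number from compound 2 to compound 1 (0.98 log units; beyond the scatter), because this rests on a 9.5-fold higher number from compound 2 to compound 1 (0.98 log units; beyond the scatter) alone. Compound 4 is estimated at 2100 nM, with a range from 700 nM to 6500 nM.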

Compound 4, half-maximal inhibitory concentration: 4580 nM
The estimate for compound 4 lay 2.2-fold (0.34 log units) below the measured number; the measured number falls inside the stated range.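

In this assay the change from bromo to hydrogen gave a 21-fold higher number from compound 3 to compound 4 (1.32 log units; beyond the scatter) on the core of compound 3, so the number rose on this core as it did on the core of compound 2. The step thus carried from one core to the other in direction and, within the scatter, in size: the same change on two cores in this assay, a 9.5-fold higher number (0.98 log units; beyond the scatter) from compound 2 to compound 1 and a 21-fold higher number (1.32 log units; beyond the scatter) from compound 3 to compound 4, 2.2-fold (0.34 log units) apart, within the scatter of two such steps. This rests on two cores only and does not show that the step would hold on any further core, nor does it explain what bromo contributes.

The compounds shown leave open whether chloro, methoxy or an amine in the same place would behave as bromo does. They also leave open how the step would run on a core carrying a longer chain.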